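Dichlorophenyl for fluorophenyl on the saturated ring carbon

A few compounds are considered here, and "the series" means these few. Any claim that something is new, unique, unknown or untested is made for them only; others in the source may bear on it.

Measured so far:
compound 1 `COc1cc(C2=NN(C(C)=O)C(c3cccc(F)c3)O2)cc(OC)c1OC`: 16.5%
compound 2 `COc1cc(C(=O)N/N=C/c2ccc(F)c(F)c2)cc(OC)c1OC`: 35.1%
compound 3 `COc1cc(/C=N/NC(=O)c2cc(OC)c(OC)c(OC)c2)cc(OC)c1OC`: 8.5%

In a functional assay on PC-3 cells (Homo sapiens) for antiproliferative activity, read by MTT assay, tested at 1 uM (on this read-out higher numbers stand for a stronger effect at the one concentration tested and lower numbers for a weaker effect), compound 1 gives 16.5%. Of the three numbers it sits between the others: the gap to compound 3 is within the usual scatter, so the two cannot be told apart, while compound 2 stands beyond the scatter above it. No pair of these compounds differs in a single place, so no step between measured compounds is available, and compound 2 and compound 3 share no single-point relation with compound 1 that could guide the next change.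

Compound 4 `COc1cc(C2=NN(C(C)=O)C(c3ccc(Cl)c(Cl)c3)O2)cc(OC)c1OC` is not yet measured. It differs from compound 1 in one place: 3,4-dichlorophenyl in place of 3-fluorophenyl on a saturated ring carbon.

Among the measured compounds shown here, no measured step speaks to this kind of exchange. The expected step from compound 1 to compound 4 in this assay, a number 5.5 percentage points higher from compound 1 to compound 4 (within the scatter), is therefore estimated as small and within the scatter, with no confident direction. Compound 4 is expected to give about 22%, in a range from 8% to 40%.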

Compound 4, a percentage reported as inhibition, at one concentration (the size of the read-out at that concentration, not a potency): 28.1%
Compound 4: the middle estimate sits 6.1 percentage points below what was measured; the range from low to high includes it.
By their numbers in this assay, from the lowest: compounds 3 and 1 (each within the scatter of the next); then compounds 4 and 2 (each within the scatter of the next).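

With 3,4-dichlorophenyl in place of 3-fluorophenyl on the saturated ring carbon, this assay shows a number 11.6 percentage points higher from compound 1 to compound 4 (beyond the scatter) and gives the series its first readable single-place step. The aryl group on this carbon therefore has a bearing on the read-out, and this exchange raises it rather than lowers it, though the step is modest and rests on one concentration, so it speaks to the size of the effect and not to potency. Nothing on hand tells whether the step comes from the two chlorines or from the loss of the fluorine.

Open, from the compounds shown here alone, is whether a phenyl with a single chlorine, a methoxyphenyl or a pyridyl on this carbon would move the read-out the same way. Also open, going by these compounds, is how the acetyl group on the ring nitrogen would behave if replaced by a longer chain such as propanoyl.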